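This account rests on a few compounds, and the source may have more. Where it says the series, first, only, none or still open, it means among the compounds named here.

Measured so far in a functional assay on DU-145 cells (Homo sapiens) for inhibition, read by trypan blue exclusion, with a stated time of 96 h; a higher number here means a weaker inhibitor of growth, a lower number a stronger inhibitor of growth:
- compound 1 (`O=C(/C(=C\c1ccc(Br)c(O)c1)Sc1ccc(Br)cc1)c1ccc(Br)cc1`) : 1000 nM
- compound 2 (`O=C(/C(=C\c1ccc(F)cc1F)Sc1ccc(Br)cc1)c1ccc(Br)cc1`) : 1000 nM

Compound 2, at 1000 nM, stands level with compound 1 at the digits given. Next in the series is compound 3 (`O=C(/C(=C\c1ccc(F)cc1Cl)Sc1ccc(Br)cc1)c1ccc(Br)cc1`), which differs from compound 2 as follows: chloro in place of fluoro on an aromatic carbon. This is chloro in place of fluoro on an aromatic carbon, ortho to a large group and meta to a fluoro group, so 2,4-difluorophenyl becomes 2-chloro-4-fluorophenyl.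

Going by the values given here, only one measured step bears on this, and only indirectly: no change at the digits printed from compound 1 to compound 2 (within the scatter). That step exchanged 4-bromo-3-hydroxyphenyl for 2,4-difluorophenyl at the same place and stays within the scatter. Among the compounds with values here, no measured pair compares chloro with fluoro directly, and two compounds are a thin basis, so the range is kept wide. In this assay, no step beyond the scatter is expected, and neither direction is favoured.

The expected result is no change at the digits printed from compound 2 to compound 3 (within the scatter). For compound 3 the estimated value is 1000 nM. The estimated range for compound 3 runs from 400 nM to 2500 nM.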

Compound 3, concentration for 50% growth inhibition: 1000 nM
The estimate for compound 3 equals the measured number at the digits printed; the measured number falls inside the stated range.
By their numbers in this assay, from the lowest: compounds 1, 2 and 3 (each within the scatter of the next).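

In this assay, the aromatic carbon ortho to a large group now has a direct comparison of two halogens: chloro in place of fluoro gives no change at the digits printed from compound 2 to compound 3 (within the scatter), so this exchange at this place does not separate the two compounds. The broader exchange of 4-bromo-3-hydroxyphenyl for 2-chloro-4-fluorophenyl gives no change at the digits printed from compound 1 to compound 3 (within the scatter), which adds a second replacement of that group that stays within the scatter, alongside the 2,4-difluorophenyl case. No measurement available here explains this level result.

The ring patterns shown carry only halogen and hydroxy groups, so it remains open whether an amine, a carboxylic acid or a methoxy group on the same aromatic carbon would depart from this level reading. Going by these compounds, it also remains open whether the insensitivity to chloro and fluoro at this place would hold if the rest of the shared core were changed.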